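Swapping a phenylethyl for an ester-bearing chain

This account rests on a few compounds, and the source may have more. Where it says the series, first, only, none or still open, it means among the compounds named here.

Measured so far, in a functional assay on HL-60 cells (Homo sapiens), with a stated time of 2 days; a lower number here means a stronger inhibitor, a higher number a weaker inhibitor:
Compound 1 `O=C(NCc1ccc(-c2ccccc2)cc1)c1nc[nH]c1C(=O)Nc1ccc(Cl)c(Cl)c1` gives 7000 nM.
Compound 2 `C[C@@H](NC(=O)c1[nH]cnc1C(=O)Nc1ccc(Cl)c(Cl)c1)c1ccccc1` gives 8800 nM.
Compound 3 `C[C@H](NC(=O)c1[nH]cnc1C(=O)Nc1ccc(Cl)c(Cl)c1)c1ccccc1` gives 9200 nM.

Compound 3 shows the highest number of the three, but its gaps to compound 2 and to compound 1 both lie within the scatter of this assay, so the three compounds cannot be told apart on these values. Among the compounds with values here, the one directly comparable pair is compound 2 and compound 3: a 1.0-fold higher number from compound 2 to compound 3 (0.02 log units; within the scatter), which is what one would expect given (the fact that compounds 2 and 3 differ only in the configuration as drawn).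

Compound 4 `COC(=O)[C@H](NC(=O)c1[nH]cnc1C(=O)Nc1ccc(Cl)c(Cl)c1)C(C)C` carries a different group on the amide-type nitrogen: 1-(methoxycarbonyl)-2-methylpropyl in place of 1-phenylethyl on an amide-type nitrogen. Within the data shown here, no measured step touches this kind of change. Among the measured compounds shown here, the only measured step, the stereochemical one, tells nothing about exchanging the aromatic side group for an ester-bearing chain, and every compound seen so far carries an aromatic group at that place. With no guidance either way, the expectation is a step no larger than the scatter, a 1.1-fold higher number from compound 3 to compound 4 (0.04 log units; within the scatter), with a wide range to cover the unknown. The estimate for compound 4 in this assay is therefore 10000 nM, expected to fall between 3000 nM and 35000 nM.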

Compound 4, half-maximal inhibitory concentration: 8500 nM
Compound 4: middle estimate off by 1.2-fold (0.07 log units), on the high side, and the stated range covers the measured number.
By their numbers in this assay, from the lowest: compounds 1, 4, 2 and 3 (each within the scatter of the next).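

In this assay, the exchange of 1-phenylethyl for 1-(methoxycarbonyl)-2-methylpropyl on the amide-type nitrogen gives two steps, both within the scatter (  a 1.1-fold lower number from compound 3 to compound 4 (0.03 log units; within the scatter)  and  a 1.0-fold lower number from compound 2 to compound 4 (0.02 log units; within the scatter)  ). Until now every compound carried an aromatic ring at this place, so the data could not say whether such a ring was needed; compound 4 has no ring in this group, yet it cannot be told apart from compound 2 or compound 3, so a number of this size does not depend on an aromatic ring here. The entering group also brings an ester carbonyl and hydrogen-bond acceptors, which the leaving group lacks, and nothing on hand bears on why the exchange of so different a group leaves the read-out indistinguishable.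

Still open is whether any group at this place can move the number beyond the scatter, since all the groups shown so far give values that cannot be separated. A carboxylic acid in place of the methyl ester, an amine on the chain or a longer chain would test this, as would the opposite configuration of the 1-(methoxycarbonyl)-2-methylpropyl group.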